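Three growth inhibitors and an untested chloro analogue

The compounds below may be only part of what the source reports. "The series", "measured", "known", "first", "only" and "open" are said of these compounds alone.

Values in a functional assay on Gurav cells (Homo sapiens) for inhibition, read by sulforhodamine B assay; a higher number here means a weaker inhibitor of growth, a lower number a stronger inhibitor of growth:
- Compound 1 `FC(F)(F)c1ccc(-c2ccc(-c3ccc(-c4nc5ccccc5[nH]4)cc3)cc2)cc1`: 39100 nM
- Compound 2 `Oc1ccc(-c2ccc(-c3ccc(-c4nc5ccccc5[nH]4)cc3)cc2)cc1`: 100000 nM
- Compound 3 `Oc1cccc2[nH]c(-c3ccc(-c4ccc(-c5ccc(C(F)(F)F)cc5)cc4)cc3)nc12`: 3190 nM

Compound 3 has the lowest number of the three, making it the strongest growth inhibitor here. Compound 4 `Oc1cccc2[nH]c(-c3ccc(-c4ccc(-c5cccc(Cl)c5)cc4)cc3)nc12` carries 3-chlorophenyl in place of 4-(trifluoromethyl)phenyl on an aromatic carbon. The large step of a 12-fold lower number from compound 1 to compound 3 (1.09 log units; beyond the scatter) came with adding a hydroxy that compound 4 keeps, so it says little about this change. The closer guide is the modest step of a 2.6-fold higher number from compound 1 to compound 2 (0.41 log units; beyond the scatter), which also replaced the trifluoromethyl. Neither step tests a chlorine directly. A step within the scatter is therefore expected in this assay, leaning toward a higher number. The estimated change is a 1.4-fold higher number from compound 3 to compound 4 (0.15 log units; within the scatter). Compound 4 is expected at about 4500 nM, within an estimated range of 1300 nM to 16000 nM.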

Compound 4, concentration for 50% growth inhibition: 2310 nM
The estimate for compound 4 lay 1.9-fold (0.29 log units) above the measured number; the range from low to high includes it.
By their numbers in this assay, from the lowest: compounds 4 and 3 (each within the scatter of the next); then compound 1; then compound 2.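

In this assay, the exchange of 4-(trifluoromethyl)phenyl for 3-chlorophenyl gives a 1.4-fold lower number from compound 3 to compound 4 (0.14 log units; within the scatter), so compound 3 and compound 4 cannot be told apart. With the added hydroxy kept, this outer ring can therefore carry a different group at a different ring position without a change beyond the scatter. Nothing available explains this result.

Going by these compounds, the exchange alters the group and its ring position together, so their separate contributions remain unknown. On these data alone, how an amine or a carboxylic acid on this ring would fare also remains open.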